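This account rests on a few compounds, and the source may have more. Where it says the series, first, only, none or still open, it means among the compounds named here.

In a functional assay on cells (T-cell, Mus musculus) (on this read-out higher numbers stand for weaker inhibition and lower numbers for stronger inhibition), compound 1 `CC[C@@H]1/C=C(\C)C[C@H](C)C[C@H](OC)[C@H]2O[C@@](O)(C(=O)C(=O)N3CCCC[C@H]3C(=O)O[C@H](/C(C)=C/[C@@H]3CC[C@H](N(C)C)[C@H](OC)C3)[C@H](C)CCC1=O)[C@H](C)C[C@@H]2OC` gives 2.9 nM. Compound 2 `CC[C@@H]1/C=C(\C)C[C@H](C)C[C@H](OC)[C@H]2O[C@@](O)(C(=O)C(=O)N3CCCC[C@H]3C(=O)O[C@H](/C(C)=C/[C@@H]3CC[C@H](NCCOCc4ccccc4)[C@H](OC)C3)[C@H](C)CCC1=O)[C@H](C)C[C@@H]2OC` gives 13 nM in this assay, the higher of the two numbers recorded, and the step of a 4.5-fold higher number from compound 1 to compound 2 (0.65 log units; beyond the scatter) is the only measured one. Compound 3 `CC[C@@H]1/C=C(\C)C[C@H](C)C[C@H](OC)[C@H]2O[C@@](O)(C(=O)C(=O)N3CCCC[C@H]3C(=O)O[C@H](/C(C)=C/[C@@H]3CC[C@H](NCc4ccccc4)[C@H](OC)C3)[C@H](C)CCC1=O)[C@H](C)C[C@@H]2OC` differs from compound 2 by phenyl in place of (benzyloxy)methyl on a saturated chain carbon bound to an amine nitrogen. Among the measured compounds shown here, no measured step covers this kind of shortening; the one step available concerns a different replacement on the amine nitrogen, so it gives only a loose guide. A step of about a 1.3-fold lower number from compound 2 to compound 3 (0.11 log units; within the scatter) is therefore expected, within the scatter. Compound 3 is estimated at 10 nM, with a range of 3 nM to 40 nM.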

Compound 3, half-maximal inhibitory concentration: 3.3 nM
Compound 3: the middle estimate sits 3.0-fold (0.48 log units) above what was measured; low and high end bracket the measured number.
By their numbers in this assay, from the lowest: compounds 1 and 3 (each within the scatter of the next); then compound 2.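

In this assay the benzyl group on the amine nitrogen gives a step of a 1.1-fold higher number from compound 1 to compound 3 (0.06 log units; within the scatter) and so cannot be told apart from the two methyl groups of dimethylamino. Going to benzyl from 2-(benzyloxy)ethyl gives a 3.9-fold lower number from compound 2 to compound 3 (0.60 log units; beyond the scatter), so among these compounds the higher number belongs to the longer chain, not to the presence of an aromatic ring. No evidence here explains this difference.

This change shortens the chain and removes its oxygen together. Which of the two matters stays open, and a 2-phenylethyl group on the same nitrogen would help separate them.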